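Fluoro Added to the Phenyl of Compound 3

The source may hold more compounds than are shown below. What is called first, only, known or untested is meant among the compounds shown, and "the series" means these compounds.

Compound 1 `c1ccc(C2=NN(c3ccc(-c4ccccc4)nn3)C(c3ccccc3)C2)cc1` gives 10000 nM in a functional assay on HepG2 cells (Homo sapiens) for antiproliferative activity, read by MTT assay, with a stated time of 24 h; a higher number here means a weaker inhibitor, a lower number a stronger inhibitor. Compound 2 `Fc1ccc(C2CC(c3ccc(Cl)cc3)=NN2c2ccc(-c3ccccc3)nn2)cc1` gives 10000 nM. Compound 3 `COc1ccc(C2=NN(c3ccc(-c4ccccc4)nn3)C(c3ccccc3)C2)cc1` gives > 100000 nM, which is a limit of this assay and not a number.

Compound 3 thus stands at the limit of this assay, one of the three values sitting there (the limit of > 100000 nM in this assay, at which 1 of the 3 values shown sits), reached through the step of an at least 10-fold higher number from compound 1 to compound 3 (1.00 log units; beyond the scatter). Compound 4 `COc1ccc(C2=NN(c3ccc(-c4ccccc4)nn3)C(c3ccc(F)cc3)C2)cc1` differs from compound 3 by fluoro in place of hydrogen on an aromatic carbon. Going by the values given here, no measured step exchanges hydrogen for fluoro; compounds 1 and 2, which differ in more than one place, both give the same reading. Among the compounds with values here, the only measured step, an at least 10-fold higher number from compound 1 to compound 3 (1.00 log units; beyond the scatter), concerns the methoxy that compound 4 keeps. Compound 4 is therefore expected to remain at the limit, with a step of a number no higher from compound 3 to compound 4 (the limit leaves the size open) not beyond the scatter. The estimate for compound 4 is 100000 nM, between 30000 nM and 300000 nM.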

Compound 4, half-maximal inhibitory concentration: 9160 nM
Compound 4: middle estimate off by 11-fold (1.04 log units), on the high side, outside the stated range (below it).
By their numbers in this assay, from the lowest: compounds 4, 1 and 2 (each within the scatter of the next). At a limit, above all of these: compound 3.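

In this assay, going by these compounds alone, fluoro in place of hydrogen on this phenyl gives a reading that is a number again (an at least 10-fold lower number from compound 3 to compound 4 (1.03 log units; beyond the scatter)), a change that no earlier pair isolated. With that fluoro kept, methoxy in place of chloro makes no difference beyond the scatter (a 1.1-fold lower number from compound 2 to compound 4 (0.04 log units; within the scatter)), so the rise seen earlier with methoxy (an at least 10-fold higher number from compound 1 to compound 3 (1.00 log units; beyond the scatter)) does not carry over here. Compound 3 stands at a limit, so the size of the first step is only a bound: the limit of > 100000 nM in this assay, at which 1 of the 4 values shown sits.

From the compounds shown here alone, whether fluoro does the same without the methoxy stays open. So does the outcome with an amine or a carboxylic acid on this phenyl.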